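Swapping phenyl for benzyl on a ring nitrogen

The compounds below may be only part of what the source reports. "The series", "measured", "known", "first", "only" and "open" are said of these compounds alone.

Three compounds share a core in which an amide links an aminophenyl group to a benzyl sulfur that carries a thiocarbonyl on a cyclic amine. Compound 1 is `Nc1ccccc1NC(=O)c1ccc(CSC(=S)N2CCN(c3ccccc3)CC2)cc1`; compound 2 is `Nc1ccccc1NC(=O)c1ccc(CSC(=S)N2CCCC2)cc1`; compound 3 is `COC(=O)c1ccc2c(c1)CCN2C(=S)SCc1ccc(C(=O)Nc2ccccc2N)cc1`. In a functional assay on MGC-803 cells (Homo sapiens) for antiproliferative activity, read by CCK-8 assay, with a stated time of 72 h, tested at 8 uM (on this read-out lower numbers stand for a weaker effect and higher numbers for a stronger effect at the one concentration tested), compound 1 gives 87.4%, the largest of the three numbers. Compound 2 gives 83.4%, which lies within the usual scatter of compound 1, so the two cannot be told apart. Compound 3 gives 73.1%, a number that sits beyond the scatter below compound 1.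

Compound 4 is `Nc1ccccc1NC(=O)c1ccc(CSC(=S)N2CCN(Cc3ccccc3)CC2)cc1`. It differs from compound 1 in one place: benzyl in place of phenyl on an amine nitrogen in a ring. Going by the values given here, no pair of measured compounds that differ only in this way has been tested, so no measured step guides the expectation. Given that compound 1 gives 87.4% and that compound 2, with a smaller ring amine, gives 83.4%, the expected change is small, none beyond the scatter, in either direction. Compound 4 is expected to give 85%, between 72% and 94%. This estimate means a step of a number 2.4 percentage points lower from compound 1 to compound 4 (within the scatter), within the scatter.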

Compound 4, a percentage reported as inhibition, at one concentration (the size of the read-out at that concentration, not a potency): 19.7%
For compound 4 the middle estimate is 65.3 percentage points above the measured one; the measured number lies below the stated range.
By their numbers in this assay, from the lowest: compound 4; then compound 3; then compounds 2 and 1 (each within the scatter of the next).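

In this assay, benzyl in place of phenyl on an amine nitrogen in a ring gives a number 67.7 percentage points lower from compound 1 to compound 4 (beyond the scatter) and so is far from a neutral swap at this position. The two groups look much alike on paper: each has one six-membered aromatic ring of carbon only, no hydrogen-bond donors or acceptors and no net charge, and benzyl has 7 heavy atoms where phenyl has 6. No measurement here offers an explanation for so large a step.

The compounds shown leave open how the read-out responds to other groups on this nitrogen, such as a methyl group or a longer chain like phenethyl. They also leave open whether an amine or a carboxylic acid on the benzyl ring of compound 4 would change the picture.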